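This account rests on a few compounds, and the source may have more. Where it says the series, first, only, none or still open, it means among the compounds named here.

In a functional assay on MCF7 cells (Homo sapiens) for inhibition, read by sulforhodamine B assay (a higher number here means a weaker inhibitor, a lower number a stronger inhibitor), compound 1 `O=C1C(Nc2ccc(I)cc2)=CC(=O)c2c1nc1n2[C@H]2OC[C@@H](O)[C@H]2OC1` gives 3890 nM. Compound 2 `CCOc1ccc(NC2=CC(=O)c3c(nc4n3[C@H]3OC[C@@H](O)[C@H]3OC4)C2=O)cc1` is reported only as a limit, > 4000 nM. Compound 3 `CCCc1ccc(NC2=CC(=O)c3c(nc4n3[C@H]3OC[C@@H](O)[C@H]3OC4)C2=O)cc1` carries propyl in place of ethoxy on an aromatic carbon, para to a large group: propyl in place of ethoxy on an aromatic carbon. Among the compounds with values here, only one measured step bears on this change, an at least 1.0-fold higher number from compound 1 to compound 2 (0.01 log units; that floor lies within the scatter), and it replaced iodo with ethoxy at that same carbon, so it gives no ground for expecting a clear shift in either direction in this assay. The expected step is an at least 1.0-fold lower number from compound 2 to compound 3 (0.02 log units; that floor lies within the scatter), none beyond the scatter. For compound 3 the estimate is 3800 nM, with an expected range from 1800 nM to 8000 nM.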

Compound 3, half-maximal inhibitory concentration: > 4000 nM
Compound 3 ended at the assay's limit (the forecaster's own chance of this, stated with the estimate: 55%); middle value at least 1.0-fold (0.02 log units) from the limit.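

In this assay compound 3 is reported only as a limit, > 4000 nM, and the step from compound 2 to compound 3 cannot be read. Propyl in place of iodo on this aromatic carbon gives an at least 1.0-fold higher number from compound 1 to compound 3 (0.01 log units; that floor lies within the scatter), so a chain of carbon only, like ethoxy, shows no shift beyond the scatter. Any difference between ethoxy and propyl stays hidden because both compounds rest on the same limit: the limit of > 4000 nM in this assay, at which 2 of the 3 values shown sit.

Going by these compounds, how an amine, a carboxylic acid or a chain longer than propyl would read on this carbon remains open. So does whether any group here would give a clearly stronger inhibitor than compound 1.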